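This account rests on a few compounds, and the source may have more. Where it says the series, first, only, none or still open, it means among the compounds named here.

Working notes on the series. Three members of the shared core, each bearing a nitrile and two amino groups, have been measured in a physicochemical assay for solubility, in phosphate buffer, with a stated time of 18 h; a higher number here means a more soluble compound, a lower number a less soluble compound. Compound 1 `N#Cc1c(N)nc2nc(C3CC3)ncc2c1N` gives 23000 nM. For the measured compounds named here, compound 2 `N#Cc1c(N)nc2nc(C3CCCCC3)ncc2c1N` gives 81000 nM; the single one-point step so far, a 3.5-fold higher number from compound 1 to compound 2 (0.55 log units; beyond the scatter), is the change of cyclohexyl in place of cyclopropyl on an aromatic carbon. Compound 3 `CCCCc1nc(C(C)(C)C)nc2nc(N)c(C#N)c(N)c12` gives 6000 nM, the lowest of the three numbers: the gap to compound 1 is beyond the scatter, and the gap to compound 2 is wider still.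

Compound 4 `CC(C)(C)c1nc(-c2ccncc2)c2c(N)c(C#N)c(N)nc2n1` is the next member to be measured. It differs from compound 3 by pyridin-4-yl in place of butyl on an aromatic carbon. Going by the values given here, no measured step bears on an exchange of this kind; the one known step, a 3.5-fold higher number from compound 1 to compound 2 (0.55 log units; beyond the scatter), concerns two saturated rings and was modest. Nothing here therefore fixes the size or direction of the step from compound 3 to compound 4, and a move no larger than modest, in either direction, is the working expectation. Compound 4 is expected to give about 9000 nM in this assay, within 3000 nM to 27000 nM. That estimate corresponds to an expected 1.5-fold higher number from compound 3 to compound 4 (0.18 log units; within the scatter).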

Compound 4, solubility: 44000 nM
Compound 4: middle estimate off by 4.9-fold (0.69 log units), on the low side; the measured number lies above the stated range.
By their numbers in this assay, from the lowest: compound 3; then compounds 1, 4 and 2 (each within the scatter of the next, the first and the last beyond it).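

In this assay, the exchange of butyl for pyridin-4-yl on the aromatic carbon next to the ring nitrogen and meta to a tert-butyl group gives a 7.3-fold higher number from compound 3 to compound 4 (0.87 log units; beyond the scatter), so this place on the shared core is not silent to its substituent in this read-out. For the compounds shown here, this is the first measured change at this place, and it replaces an open chain with no ring by a six-membered aromatic ring holding one hetero atom, an exchange of a different kind from the swap of one saturated ring for another seen earlier at another place. Nothing measured on these compounds accounts for the higher number, so the step stands as an observation on one pair, with a tert-butyl group present in both.

The compounds shown leave open whether the ring nitrogen matters or the aromatic ring alone would give a similar step, which phenyl or pyridin-3-yl at the same place would separate. They also leave open how a shorter chain, or a ring carrying an amine or a carboxylic acid, would read here, and whether the step holds without the tert-butyl group.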